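Trading a Methyl for Hydrogen on a Phenol Oxygen

A few compounds are considered here, and "the series" means these few. Any claim that something is new, unique, unknown or untested is made for them only; others in the source may bear on it.

Of the compounds shown here, three built on one shared core have been tested in a functional assay on NCI-H522 cells (Homo sapiens) for inhibition, read by sulforhodamine B assay, with a stated time of 48 h; a higher number here means a weaker inhibitor of growth, a lower number a stronger inhibitor of growth. Compound 1 `COc1cc(C)cc(-c2c(-c3ccnc(-c4ccc(N(C)C)cc4)c3)cnn2CC#N)c1` gives 27 nM, compound 2 `COc1cc(C)cc(-c2nn(CC#N)cc2-c2ccnc(-c3ccc(N(C)C)cc3)c2)c1` gives 196 nM, and compound 3 `COc1cc(C)cc(-c2nn(CC#N)cc2-c2ccc(-c3cccc(C(C)=O)c3)nc2)c1` gives 1640 nM. Compound 2 thus stands second highest of the three numbers, and its gaps to compound 1 and to compound 3 both lie beyond the scatter. Compound 4 `Cc1cc(O)cc(-c2nn(CC#N)cc2-c2ccnc(-c3ccc(N(C)C)cc3)c2)c1` is the next compound: it differs from compound 2 by hydrogen in place of methyl on an oxygen on an aromatic ring, which read one bond further out is methoxy to hydroxy. Within the data shown here, no measured pair shows this change, so its effect is unknown here. The step of a 1.5-fold higher number from compound 2 to compound 4 (0.18 log units; within the scatter) is expected to be small, a slight weakening that may stay within the scatter. Compound 4 is therefore estimated at 300 nM, with a range from 100 nM to 1000 nM.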

Compound 4, concentration for 50% growth inhibition: 1930 nM
Compound 4: middle estimate off by 6.4-fold (0.81 log units), on the low side; the measured number lies above the stated range.
By their numbers in this assay, from the lowest: compound 1; then compound 2; then compounds 3 and 4 (each within the scatter of the next).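

In this assay, changing methoxy to hydroxy gives a 9.8-fold higher number from compound 2 to compound 4 (0.99 log units; beyond the scatter) and so shows that this small change is not neutral at this position. For this pair, the methyl on the oxygen of the aromatic ring goes with the stronger growth inhibition. Nothing available explains this rise in the number. On these data alone, it remains open whether an ethoxy group or an amine at this position would stay close to compound 2 or fall away as compound 4 does. As far as these compounds go, whether the same change would have a similar effect on compound 1 is also open.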